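From phenyl triazole to chloro on the side chain

The source may report more compounds than this note shows. Statements on the series, on what has been measured and on what is new or still open speak of the compounds shown alone.

compound 1 `CCCCCCCCCC(CCO)n1cnc2c(Cl)ncnc21` gives 890 nM
compound 2 `CCCCCCCCCC(CCN=[N+]=[N-])n1cnc2c(Cl)ncnc21` gives 1040 nM
compound 3 `CCCCCCCCCC(CCn1cc(-c2ccccc2)nn1)n1cnc2c(Cl)ncnc21` gives 13500 nM

These values come from a functional assay on HCT-116 cells (Homo sapiens) for antiproliferative activity, read by MTT assay, with a stated time of 48 h; a lower number here means a stronger inhibitor, a higher number a weaker inhibitor. Compound 3 has the highest number and is the weakest of the three, with large steps: a 15-fold higher number from compound 1 to compound 3 (1.18 log units; beyond the scatter) and a 13-fold higher number from compound 2 to compound 3 (1.11 log units; beyond the scatter). Compound 4 `CCCCCCCCCC(CCCl)n1cnc2c(Cl)ncnc21` has chloro in place of 4-phenyl-1H-1,2,3-triazol-1-yl on a saturated chain carbon, three bonds along the chain from an aromatic nitrogen. Swapping hydroxy for azido changed little, a 1.2-fold higher number from compound 1 to compound 2 (0.07 log units; within the scatter), but chloro itself is untested here. Chloro is therefore expected to behave more like those two groups than like the triazole, and so to undo most of the large loss. The expected step is a 12-fold lower number from compound 3 to compound 4 (1.09 log units; beyond the scatter). The estimate for compound 4 is 1100 nM, with an expected range from 450 nM to 3000 nM.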

Compound 4, half-maximal inhibitory concentration: 10200 nM
For compound 4 the middle estimate is 9.3-fold (0.97 log units) below the measured one; measured number outside the range, above it.
By their numbers in this assay, from the lowest: compounds 1 and 2 (each within the scatter of the next); then compounds 4 and 3 (each within the scatter of the next).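

In this assay, the phenyl triazole and chloro read alike, with a 1.3-fold lower number from compound 3 to compound 4 (0.12 log units; within the scatter). Chloro is separated from the other two groups, with a 9.8-fold higher number from compound 2 to compound 4 (0.99 log units; beyond the scatter) and an 11-fold higher number from compound 1 to compound 4 (1.06 log units; beyond the scatter). So the phenyl triazole is not the only group on this chain carbon that gives a high number, and losing its two rings does not by itself bring the number back down; no available evidence explains this split. Open, going by these compounds, is whether an amine or a carboxylic acid at this place would read with hydroxy and azido or with chloro and the phenyl triazole.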